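Fluoro in Place of Hydrogen: Compound 3 to Compound 4

The compounds below may be only part of what the source reports. "The series", "measured", "known", "first", "only" and "open" are said of these compounds alone.

Three compounds have been measured in a functional assay on MCF7 cells (Homo sapiens) for cytotoxicity, read by MTT assay, with a stated time of 2 days, tested at 100 uM; on this read-out higher numbers stand for a weaker effect at the one concentration tested and lower numbers for a stronger effect:
compound 1 `CC(=O)c1cc(-c2ccc(F)cc2)cc2cc(-c3ccccc3)[nH]c12` — 36.4%
compound 2 `CC(=O)c1cc(-c2ccc(F)cc2)cc2cc(-c3ccc(F)cc3)[nH]c12` — 20%
compound 3 `COc1ccc(-c2cc3cc(-c4ccccc4)cc(C(C)=O)c3[nH]2)cc1` — 43.5%

Compound 3 gives the highest of the three numbers in this assay. Its nearest neighbour is compound 1, which lies within the usual scatter of it; its furthest is compound 2, which lies beyond the scatter.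

Compound 4 `COc1ccc(-c2cc3cc(-c4ccc(F)cc4)cc(C(C)=O)c3[nH]2)cc1` is not yet measured. It differs from compound 3 in one place: fluoro in place of hydrogen on an aromatic carbon.

Within the data shown here, one measured step bears on this change. Between compound 1 and compound 2 the same change, fluoro in place of hydrogen on an aromatic carbon, gave a number 16.4 percentage points lower from compound 1 to compound 2 (beyond the scatter). Among the measured compounds shown here, compound 3 carries a methoxy group that compound 1 lacks, and no step shows how that group alters the effect of the fluoro, so the one step is the only guide. On that basis a modest step downward in this assay is expected, of a size comparable to the step seen before.

Compound 4 is therefore estimated at 27% in this assay, with a range from 14% to 40%. This estimate means an expected step of a number 16.5 percentage points lower from compound 3 to compound 4 (beyond the scatter).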

Compound 4, a percentage reported as activity, at one concentration (the size of the read-out at that concentration, not a potency): 47%
For compound 4 the middle estimate is 20 percentage points below the measured one; the measured number lies above the stated range.
By their numbers in this assay, from the lowest: compound 2; then compounds 1, 3 and 4 (each within the scatter of the next, the first and the last beyond it).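

The effect of the phenyl to 4-fluorophenyl change in this assay is not fixed but depends on the core that carries it: the same change on two cores in this assay, a number 16.4 percentage points lower (beyond the scatter) from compound 1 to compound 2 and a number 3.5 percentage points higher (within the scatter) from compound 3 to compound 4, 19.9 percentage points apart, beyond the scatter of two such steps. With the methoxy group present on the other aromatic ring, the fluoro gives only a number 3.5 percentage points higher from compound 3 to compound 4 (within the scatter), so the fall seen on the core of compound 1 does not recur here. With the 4-fluorophenyl group held constant, the group at the other site matters instead, as methoxy in place of fluoro gives a number 27 percentage points higher from compound 2 to compound 4 (beyond the scatter) and methoxy in place of hydrogen gives a number 10.6 percentage points higher from compound 1 to compound 4 (beyond the scatter), which makes the combination of fluoro at both sites the one that stands apart among these compounds.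

The compounds shown carry only hydrogen, fluoro and methoxy at that other site, so it remains open whether the fluoro step would return or stay absent with an amine, a hydroxyl group or a carboxylic acid there. Each compound also has a reading at a single concentration, which leaves open how these differences would appear across a range of concentrations.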